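Methoxy to Ethoxy on Two Different Cores

The source may report more compounds than this note shows. Statements on the series, on what has been measured and on what is new or still open speak of the compounds shown alone.

Compound 1 `CCCn1c(=O)n(CCOC)c(=O)c2[nH]cnc21`; in a functional assay (trachea) with Cavia porcellus as the target (a higher number here means that more compound is needed for the effect, a lower number that less compound is needed), compound 1 gives 700 nM.
Compound 2 `CCCn1c(=O)n(CCOCC)c(=O)c2[nH]cnc21`; in this assay compound 2 gives 70 nM.
Compound 3 `CCCn1c(=O)n(C)c(=O)c2c1ncn2CCOC`; in this assay compound 3 gives 36100 nM.

Compounds 1 and 2 share one core and differ in a single spot: methyl in place of hydrogen on a saturated chain carbon bound to an oxygen on a saturated carbon. This change produced a 10-fold lower number from compound 1 to compound 2 (1.00 log units; beyond the scatter), a step clearly larger than the usual scatter of the measurement.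

Compound 3 sits on a different core. How the core of compound 3 differs from the core of compound 1 is not broken down here; what the numbers show is that compound 3 has the highest value of the three, well beyond the scatter from both compound 1 and compound 2.

The unmeasured compound 4 `CCCn1c(=O)n(C)c(=O)c2c1ncn2CCOCC` is obtained from compound 3 by the same change: methyl in place of hydrogen on a saturated chain carbon bound to an oxygen on a saturated carbon. The place of the change is described in the same words for both pairs, so it is the same change on a different core. Going by these compounds, whether the core of compound 3 will respond as the core of compound 1 did is unknown, so the earlier step is only a rough guide. In this assay, among the compounds with values here, compound 4 is expected to show a 3.0-fold lower number from compound 3 to compound 4 (0.48 log units; beyond the scatter), a smaller step than the one seen from compound 1 to compound 2, since that step of a 10-fold lower number from compound 1 to compound 2 (1.00 log units; beyond the scatter) was measured on the other core. The estimate for compound 4 in this assay is 12000 nM, expected to lie between 3600 nM and 36000 nM.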

Compound 4, half-maximal effective concentration: 4600 nM
For compound 4 the middle estimate is 2.6-fold (0.42 log units) above the measured one; the range from low to high includes it.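

In this assay, replacing methoxy with ethoxy on the core of compound 3 gave a 7.8-fold lower number from compound 3 to compound 4 (0.89 log units; beyond the scatter), so less compound was needed for the effect after this small addition of a single methyl group. Set beside the earlier step on the other core, the two results cannot be told apart: the same change on two cores in this assay, a 10-fold lower number (1.00 log units; beyond the scatter) from compound 1 to compound 2 and a 7.8-fold lower number (0.89 log units; beyond the scatter) from compound 3 to compound 4, 1.3-fold (0.11 log units) apart, within the scatter of two such steps. For these two pairs, then, the change from methoxy to ethoxy carried over from one core to the other with about the same size of step, even though the two cores start from very different values; this does not show that a third core would respond in the same way, and two pairs alone cannot explain why the steps match.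

The compounds shown leave open how a longer chain such as propoxy, or a chain ending in an amine or a carboxylic acid, would behave on either core. They also leave open whether the two cores would keep moving in parallel with such groups, which would be needed before a step measured on one core could be relied on to predict the step on the other.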